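The source may report more compounds than this note shows. Statements on the series, on what has been measured and on what is new or still open speak of the compounds shown alone.

Among the compounds with values here, the three compounds measured so far share one core. Compound 1, `O=C(O)c1cc(-c2ccc(-c3ccc(Cl)cc3Cl)cc2)n(-c2ccc(Cl)cc2Cl)n1`, gives 11900 nM in an assay on isolated protein for inhibition of methionine--tRNA ligase, cytoplasmic (Homo sapiens) (a lower number here means a stronger inhibitor, a higher number a weaker inhibitor), the lowest of the three numbers. Compound 2, `O=C(O)c1cc(-c2ccc(-c3ccccc3)cc2)n(-c2ccc(Cl)cc2Cl)n1`, gives 44300 nM in this assay, and compound 3, `O=C(O)c1cccc(-c2ccc(-c3cc(C(=O)O)nn3-c3ccc(Cl)cc3Cl)cc2)c1`, gives 40900 nM. The step of a 3.7-fold higher number from compound 1 to compound 2 (0.57 log units; beyond the scatter) and the step of a 3.4-fold higher number from compound 1 to compound 3 (0.54 log units; beyond the scatter) each remove the 2,4-dichlorophenyl on an aromatic carbon, and each costs a modest amount. Compound 2 and compound 3 stand within the scatter of each other, as a 1.1-fold lower number from compound 2 to compound 3 (0.03 log units; within the scatter) shows.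

Compound 4, `O=C(O)Cn1nc(C(=O)O)cc1-c1ccc(-c2ccc(Cl)cc2Cl)cc1`, differs from compound 1 at another place: carboxymethyl in place of 2,4-dichlorophenyl on an aromatic nitrogen. Within the data shown here, no measured step touches the group on the aromatic nitrogen, so the measured steps bear on this change only indirectly. They show that taking away a 2,4-dichlorophenyl on the aromatic carbon weakened inhibition modestly in both cases, while here a six-membered aromatic ring gives way to a carboxymethyl with no ring at all. The chemist therefore expects a loss in this assay at least as large as either measured step, estimated as a 5.0-fold higher number from compound 1 to compound 4 (0.70 log units; beyond the scatter). The estimate for compound 4 in this assay is 60000 nM, with a range from 15000 nM to 250000 nM.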

Compound 4, half-maximal inhibitory concentration: 100000 nM
Estimate against measurement, compound 4: 1.7-fold (0.22 log units) below; the measured number falls inside the stated range.
By their numbers in this assay, from the lowest: compound 1; then compounds 3 and 2 (each within the scatter of the next); then compound 4.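

Until compound 4, every measured step changed a group on an aromatic carbon, while the 2,4-dichlorophenyl on the aromatic nitrogen stayed in place. The new result, an 8.4-fold higher number from compound 1 to compound 4 (0.92 log units; beyond the scatter) in this assay, shows that this position also affects the number: exchanging that group for carboxymethyl weakens inhibition, and compound 4 has the highest number of the four compounds. The change, however, removes the six-membered aromatic ring, reduces the number of heavy atoms and introduces a hydrogen-bond donor and acceptor all at once, and no measurement available here explains the loss.

The compounds shown leave open whether the loss follows from losing the aromatic ring or from adding the carboxylic acid, a question that an unsubstituted phenyl, a methyl or a methyl ester at this position would help to separate. They also leave open whether the two chlorines on this ring matter, as a comparison between the 2,4-dichlorophenyl and an unsubstituted phenyl on the aromatic nitrogen would show.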